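The compounds below may be only part of what the source reports. "The series", "measured", "known", "first", "only" and "open" are said of these compounds alone.

The study concerns a shared core that carries a 3-hydroxyphenyl group, a chlorophenyl group and a third aromatic ring. Compound 1 `Oc1cccc(-c2cc(-c3ccc(Cl)cc3)nc(-c3cccs3)c2)c1` serves as the reference: in an ADME assay on HEK293 cells (Homo sapiens) for cytotoxicity, read by CCK-8 assay and cell counting, with a stated time of 2 days (a higher number here means a weaker inhibitor, a lower number a stronger inhibitor), compound 1 gives 11800 nM. For the measured compounds named here, compound 2 `Oc1cccc(-c2cc(-c3cccc(Cl)c3)nc(-c3cccs3)c2)c1` differs from it only in the chlorophenyl group, and in this assay compound 2 gives 3150 nM; the step of a 3.7-fold lower number from compound 1 to compound 2 (0.57 log units; beyond the scatter) is the only measured step in the set. Compound 3 `Oc1cccc(-c2cc(-c3cccnc3)nc(-c3cccc(Cl)c3)c2)c1` is a further member, but in this assay compound 3 gives "not determined" (no result reported). Among the two numbers that exist, compound 1 therefore stands highest, with compound 2 the nearest and lower entry.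

Compound 4 `Oc1cccc(-c2cc(-c3ccncc3)nc(-c3ccc(Cl)cc3)c2)c1` has not yet been measured. It differs from compound 1 in the third aromatic ring: pyridin-4-yl in place of thiophen-2-yl on an aromatic carbon. Going by the values given here, the single measured step concerns the chlorophenyl group, not the ring exchanged here, so no measured step bears directly on this change; that step only shows that a single exchange in this set can shift the number beyond the scatter. Without a relevant comparison, the expected step of a 1.1-fold lower number from compound 1 to compound 4 (0.03 log units; within the scatter) is none beyond the scatter, with wide uncertainty. Compound 4 is estimated at 11000 nM, within a range from 3500 nM to 35000 nM.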

Compound 4, half-maximal inhibitory concentration: 2890 nM
The estimate for compound 4 lay 3.8-fold (0.58 log units) above the measured number; the measured number lies below the stated range.
By their numbers in this assay, from the lowest: compounds 4 and 2 (each within the scatter of the next); then compound 1.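

In this assay, for the compounds shown here, replacing thiophen-2-yl with pyridin-4-yl gives a 4.1-fold lower number from compound 1 to compound 4 (0.61 log units; beyond the scatter), so the place next to the ring nitrogen also responds to a single exchange, beyond the scatter; the only earlier step concerned the chlorophenyl group. The exchange changes a five-membered aromatic ring with a sulfur atom into a six-membered aromatic ring with a nitrogen atom, while the counts of hydrogen-bond donors and acceptors stay the same, so this one step cannot separate ring size from the identity of the hetero atom. Nothing available here accounts for the size or direction of the step.

The compounds shown leave open whether a plain phenyl group, with no hetero atom, or a furan-2-yl group, which keeps the five-membered ring but has oxygen in place of sulfur, would follow compound 1 or compound 4 at this place. From the compounds shown here alone, it also remains open whether a non-aromatic group such as morpholine or a simple amine would be tolerated there, and whether the same exchange would give a similar step with the 3-chlorophenyl group of compound 2 in place of the 4-chlorophenyl group.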